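The source may report more compounds than this note shows. Statements on the series, on what has been measured and on what is new or still open speak of the compounds shown alone.

All three measured compounds share the same core, and none of them inhibits the enzyme strongly. For the measured compounds named here, in an assay on isolated protein for inhibition of Dihydrofolate reductase (Homo sapiens) (a lower number here means a stronger inhibitor, a higher number a weaker inhibitor), compound 3, with the structure `COC(=O)C(C)(C)C1c2ccccc2C=NN1C(=O)/C=C/c1cc(Cc2cnc(N)nc2N)cc(OC)c1OC`, gives 813000 nM, which is the only actual number among the three. Compound 1, `COc1cc(Cc2cnc(N)nc2N)cc(/C=C/C(=O)N2N=Cc3ccccc3C2c2ccc(CO)cc2)c1O`, reaches only the limit > 24000 nM in this assay, as recorded in the limit of > 24000 nM in this assay, at which 1 of the 3 values shown sits. Compound 2, `COc1cc(Cc2cnc(N)nc2N)cc(CCC(=O)N2N=Cc3ccccc3C2C)c1OC`, likewise stops at the limit > 28000 nM in this assay, as recorded in the limit of > 28000 nM in this assay, at which 1 of the 3 values shown sits. So compound 3 stands as the one compound with a measured value, and that value is very weak.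

Compound 4, `COc1cc(Cc2cnc(N)nc2N)cc(/C=C/C(=O)N2N=Cc3ccccc3C2CCCO)c1OC`, has not yet been measured. It differs from compound 3 in one place: 3-hydroxypropyl in place of 1-(methoxycarbonyl)-1-methylethyl on a saturated ring carbon. The change sits on a saturated ring carbon of a six-membered non-aromatic ring with 2 nitrogen, part of a fused or bridged system of two rings. Going by the values given here, no measured pair in this set shows what such a swap does, so the expectation rests only on how weak compound 3 is. A small gain in potency is expected, but the step of a 2.7-fold lower number from compound 3 to compound 4 (0.43 log units; beyond the scatter) is estimated to lie barely beyond the scatter, if at all. Compound 4 is therefore expected to give about 300000 nM in this assay, between 40000 nM and 2500000 nM.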

Compound 4, half-maximal inhibitory concentration: > 25000 nM
Compound 4 was reported as a limit; the forecaster's own chance of this, stated with the estimate: 50%; the middle value does not contradict the limit.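

In this assay compound 4 gives only a limit, > 25000 nM. This limit is not a number, so the step from compound 3 to compound 4 cannot be read. The compounds shown leave open how far 3-hydroxypropyl in place of 1-(methoxycarbonyl)-1-methylethyl on a saturated ring carbon changes inhibition of the enzyme.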